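A few compounds are considered here, and "the series" means these few. Any claim that something is new, unique, unknown or untested is made for them only; others in the source may bear on it.

In an ADME assay on microsomes from liver (Mus musculus) for metabolic stability, read by LC-MS, with a stated time of 10 min (on this read-out lower numbers stand for a less stable compound and higher numbers for a more stable compound), compound 2 `CN(C[C@H]1Cc2c(cccc2N2CCN(Cc3ccccn3)CC2)CN1)[C@H]1CCCc2cccnc21` stands highest of the two measured compounds at 40.4%, while compound 1 `CN(C[C@H]1Cc2c(cccc2N2CCN(C3CC3)CC2)CN1)[C@H]1CCCc2cccnc21` gives 7%. Compound 3 `CCN1CCN(c2cccc3c2C[C@H](CN(C)[C@H]2CCCc4cccnc42)NC3)CC1` carries methyl in place of pyridin-2-yl on a saturated chain carbon bound to an amine nitrogen in a ring, methyl in place of pyridin-2-yl on a saturated chain carbon bound to an amine nitrogen in a ring, so ethyl replaces (pyridin-2-yl)methyl. Among the compounds with values here, the only measured step that bears on this is the large a number 33.4 percentage points higher from compound 1 to compound 2 (beyond the scatter), which introduced that same (pyridin-2-yl)methyl group. A large fall is therefore expected, estimated as a number 27.4 percentage points lower from compound 2 to compound 3 (beyond the scatter). The expected value for compound 3 is 13%, ranging from 3% to 32%.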

Compound 3, percent of the compound remaining: 18.8%
Compound 3: middle estimate off by 5.8 percentage points, on the low side; low and high end bracket the measured number.
By their numbers in this assay, from the lowest: compound 1; then compound 3; then compound 2.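

The read-out in this assay responds even without an aromatic ring on this amine nitrogen in a ring: ethyl in place of cyclopropyl gives a number 11.8 percentage points higher from compound 1 to compound 3 (beyond the scatter). Replacing (pyridin-2-yl)methyl with ethyl gives a number 21.6 percentage points lower from compound 2 to compound 3 (beyond the scatter), so only part of the higher number of compound 2 is lost with the pyridin-2-yl ring. Nothing available explains either step. On these data alone, whether a benzyl group or a longer chain such as propyl would match (pyridin-2-yl)methyl or ethyl at this nitrogen stays open.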